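A few compounds are considered here, and "the series" means these few. Any claim that something is new, unique, unknown or untested is made for them only; others in the source may bear on it.

In an ADME assay on L929 cells (Mus musculus) for cytotoxicity, read by resazurin assay, with a stated time of 72 h (a lower number here means a stronger inhibitor, a higher number a weaker inhibitor), compound 1 `OB1OCc2ccc(-n3ccc4ccccc43)cc21` gives > 10 ug/mL as a limit, not a number. Compound 2 `OB1OCc2ccc(-n3cc(Sc4ccc(Cl)c(Cl)c4)c4ccccc43)cc21` gives > 10 ug/mL as a limit as well. Compound 3 `OB1OCc2ccc(-n3cc(Sc4cccc(Cl)c4)c4ccccc43)cc21` gives > 10 ug/mL as a limit too, so it has no number of its own and stands with the others (the limit of > 10 ug/mL in this assay, at which 3 of the 3 values shown sit).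

Compound 4 `O=[N+]([O-])c1ccc(Sc2cn(-c3ccc4c(c3)B(O)OC4)c3ccccc23)cc1` carries 4-nitrophenyl in place of 3-chlorophenyl on a sulfur. Within the data shown here, the steps that bear on this are a step that the two limits leave unreadable from compound 1 to compound 2 and a step that the two limits leave unreadable from compound 1 to compound 3 and a step that the two limits leave unreadable from compound 2 to compound 3 and none has a readable size. They therefore give no expected size or direction for a step in this assay beyond the scatter. The expected change is a step that the limit leaves unreadable from compound 3 to compound 4 with no direction foreseen. For compound 4 the estimated value is 15 ug/mL with an expected range from 6 ug/mL to 40 ug/mL and a limit is the likeliest report.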

Compound 4, half-maximal inhibitory concentration: > 10 ug/mL
Compound 4: a limit, no number; the forecaster's own chance of this, stated with the estimate: 70%; the middle value does not contradict the limit.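

In this assay compound 4 gives > 10 ug/mL, a limit and not a number. The steps to compound 4 from compound 2 and compound 3 cannot be read. On these data alone, whether compound 1, compound 2, compound 3 and compound 4 differ at all in this read-out remains open.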